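The source may report more compounds than this note shows. Statements on the series, on what has been measured and on what is new or still open speak of the compounds shown alone.

Measured so far in a functional assay on SK-OV-3 cells (Homo sapiens) for inhibition, read by sulforhodamine B assay, with a stated time of 48 h; a higher number here means a weaker inhibitor of growth, a lower number a stronger inhibitor of growth:
compound 1 `COc1cc(-c2cc(/C=C/C(=O)c3ccc(N)cc3)[nH]n2)cc(OC)c1OC` gives 2990 nM
compound 2 `COc1ccc(-c2cc(/C=C/C(=O)c3ccc(OC)c(OC)c3)[nH]n2)cc1` gives 5560 nM
compound 3 `COc1cc(-c2cc(/C=C/C(=O)c3ccc(Cl)c(Cl)c3)[nH]n2)cc(OC)c1OC` gives 4190 nM

All three numbers lie within the scatter of one another, so compound 1 is not set apart from compound 2 or compound 3 in this assay. Among the measured compounds shown here, the one single-point step, a 1.4-fold higher number from compound 1 to compound 3 (0.15 log units; within the scatter), changes the aryl on the carbonyl and says nothing about the other ring.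

Compound 4 `COc1ccc(-c2cc(/C=C/C(=O)c3ccc(N)cc3)[nH]n2)cc1OC` differs from compound 1 by hydrogen in place of methoxy on an aromatic carbon. For the measured compounds named here, no measured step concerns this ring. Compound 2 carries fewer methoxy groups on it but also a different carbonyl aryl, and its number is within the scatter of compound 1. The expectation for compound 4 is therefore no step beyond the scatter, a 1.2-fold higher number from compound 1 to compound 4 (0.07 log units; within the scatter). Compound 4 is estimated at 3500 nM, between 1500 nM and 8500 nM.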

Compound 4, concentration for 50% growth inhibition: 4860 nM
The estimate for compound 4 lay 1.4-fold (0.14 log units) below the measured number; the measured number falls inside the stated range.
By their numbers in this assay, from the lowest: compounds 1, 3, 4 and 2 (each within the scatter of the next).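

In this assay, among the compounds shown here, hydrogen in place of methoxy on an aromatic carbon ortho to a methoxy group gives a 1.6-fold higher number from compound 1 to compound 4 (0.21 log units; within the scatter) and is the first step measured on this ring. With 4-aminophenyl on the carbonyl, this methoxy group is therefore not shown to be needed to keep the number within the scatter. No supporting measurement bears on this step.

Still open, as far as these compounds go, is how this position responds to a hydroxyl group, a fluorine atom or a longer chain such as ethoxy. Also open, from the compounds shown here alone, is whether the same change reads alike with 3,4-dichlorophenyl on the carbonyl.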